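Swapping 3,4-difluorophenyl for 4-(dimethylamino)phenyl

The source may hold more compounds than are shown below. What is called first, only, known or untested is meant among the compounds shown, and "the series" means these compounds.

Of the compounds shown here, three sharing one core have been measured so far. In a functional assay on MKN-45 cells (Homo sapiens) for inhibition, with a stated time of 72 h (on this read-out higher numbers stand for weaker inhibition and lower numbers for stronger inhibition), compound 1 (`COc1ccc(S(=O)(=O)N2CCc3cccc(-c4ccc(N)cc4)c32)cc1`), which carries 4-aminophenyl, gives 162 nM and has the highest number of the three. With 4-nitrophenyl, compound 2 (`COc1ccc(S(=O)(=O)N2CCc3cccc(-c4ccc([N+](=O)[O-])cc4)c32)cc1`) gives 34 nM in this assay and is clearly stronger than compound 1. With 3,4-difluorophenyl, compound 3 (`COc1ccc(S(=O)(=O)N2CCc3cccc(-c4ccc(F)c(F)c4)c32)cc1`) gives 55.5 nM and stands within the scatter of compound 2, well under compound 1.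

Compound 4 (`COc1ccc(S(=O)(=O)N2CCc3cccc(-c4ccc(N(C)C)cc4)c32)cc1`) has 4-(dimethylamino)phenyl in place of 3,4-difluorophenyl on an aromatic carbon and has not been measured yet. Within the data shown here, no measured compound carries this group. Its closest measured relative is the 4-aminophenyl of compound 1, so the most relevant evidence is a 2.9-fold lower number from compound 1 to compound 3 (0.47 log units; beyond the scatter) and it is modest. The change seen in a 4.8-fold lower number from compound 1 to compound 2 (0.68 log units; beyond the scatter) is also modest, while a 1.6-fold higher number from compound 2 to compound 3 (0.21 log units; within the scatter) stays within the scatter. Compound 4 should therefore lean toward compound 1, but only part of the way, since its amino group is not the same. The expected change is a 1.6-fold higher number from compound 3 to compound 4 (0.21 log units; within the scatter) in this assay and is only a lean toward a higher number. Compound 4 is estimated to read 90 nM with 30 nM to 270 nM as the expected range.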

Compound 4, half-maximal inhibitory concentration: 237 nM
Estimate against measurement, compound 4: 2.6-fold (0.42 log units) below; the measured number falls inside the stated range.
By their numbers in this assay, from the lowest: compounds 2 and 3 (each within the scatter of the next); then compounds 1 and 4 (each within the scatter of the next).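

In this assay, the 4-(dimethylamino)phenyl group leaves compound 4 clearly on the weaker side of this position, with a 4.3-fold higher number from compound 3 to compound 4 (0.63 log units; beyond the scatter) and a 7.0-fold higher number from compound 2 to compound 4 (0.84 log units; beyond the scatter). Placing two methyl groups on the amino nitrogen makes no clear difference, as a 1.5-fold higher number from compound 1 to compound 4 (0.17 log units; within the scatter), so the four compounds now fall into two groups: compound 1 and compound 4 with an amino-type group, and compound 2 and compound 3 with a 4-nitrophenyl or 3,4-difluorophenyl group, and no compound shown goes against this split. No measurement available here explains the split.

The compounds shown leave open where other groups on this aromatic carbon would fall, such as 4-methoxyphenyl, which has an oxygen attached to the ring where compound 1 and compound 4 have a nitrogen, or 4-acetamidophenyl, which has a carbonyl on the amino nitrogen. Also open, from the compounds shown here alone, is whether a single fluorine, as in 4-fluorophenyl, would keep compound 3's reading or whether both fluorines are needed.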